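The source may report more compounds than this note shows. Statements on the series, on what has been measured and on what is new or still open speak of the compounds shown alone.

The numbers so far come from a functional assay on HCT-116 cells (Homo sapiens) for antiproliferative activity, read by MTT assay, with a stated time of 72 h (on this read-out lower numbers stand for stronger inhibition and higher numbers for weaker inhibition), and are these:

Compound 1 `Cc1ccccc1N1CCN(C(=S)SCc2ccc3nc(N)nc(N)c3c2)CC1` gives 11800 nM
Compound 2 `Nc1nc(N)c2cc(CSC(=S)N3CCN(c4ccc(F)cc4)CC3)ccc2n1` gives 3270 nM

Compound 2 holds the lower of these two numbers. Going by the values given here, the one measured step is a 3.6-fold lower number from compound 1 to compound 2 (0.56 log units; beyond the scatter) and came with 4-fluorophenyl in place of 2-methylphenyl on an amine nitrogen in a ring.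

Compound 3 `Nc1nc(N)c2cc(CSC(=S)N3CCN(c4ncccn4)CC3)ccc2n1` changes that same place again, with pyrimidin-2-yl in place of 4-fluorophenyl on an amine nitrogen in a ring. The count for this swap is pyrimidin-2-yl in place of 4-fluorophenyl on an amine nitrogen in a ring and the rest of the structure stays the same.

Among the compounds with values here, that single step is the only guide. Within the data shown here, it shows that a swap at this place can shift the number modestly, but no measured compound yet carries a ring with hetero atoms there, so the direction remains uncertain. Among the measured compounds shown here, a step of similar modest size is expected, with a slight lean toward a higher number, as compound 2 at 3270 nM is the lower of only two values. The estimated move is a 1.5-fold higher number from compound 2 to compound 3 (0.18 log units; within the scatter) at this stage. For compound 3 the estimate is 5000 nM with an expected range from 1500 nM to 16000 nM as the likely span.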

Compound 3, half-maximal inhibitory concentration: 5840 nM
Estimate against measurement, compound 3: 1.2-fold (0.07 log units) below; the measured number falls inside the stated range.
By their numbers in this assay, from the lowest: compounds 2 and 3 (each within the scatter of the next); then compound 1.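

In this assay, pyrimidin-2-yl in place of 4-fluorophenyl on the amine nitrogen in the ring gives a 1.8-fold higher number from compound 2 to compound 3 (0.25 log units; within the scatter). This shows that a ring with hetero atoms and hydrogen-bond acceptors can stand at this place with a number that cannot be told apart from that of the carbon-only ring carrying fluorine. Measured against 2-methylphenyl, the same group gives a 2.0-fold lower number from compound 1 to compound 3 (0.31 log units; beyond the scatter), a modest step, so compound 1 now has the highest number against two different groups, though nothing measured here explains these numbers.

From the compounds shown here alone, all three compounds carry a six-membered aromatic ring at this place, so it remains open how a non-aromatic group such as cyclohexyl, or a group with a carboxylic acid or a longer chain, would compare. Plain phenyl would also be needed to show, one change at a time, how much the fluorine of compound 2 and the methyl of compound 1 each contribute to their numbers.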